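This account rests on a few compounds, and the source may have more. Where it says the series, first, only, none or still open, it means among the compounds named here.

In an ADME assay on the whole organism (Rattus norvegicus) for pharmacokinetics, read by LC-MS (on this read-out higher numbers stand for higher oral bioavailability and lower numbers for lower oral bioavailability), compound 1 `COc1ccc2c(c1C(=O)OCOC(C)=O)OB(O)[C@@H](Sc1nncs1)C2` gives 52% and compound 2 `COc1ccc2c(c1C(=O)OCOC(=O)C(C)(C)C)OB(O)[C@@H](Sc1nncs1)C2` gives 100%, the higher of the two numbers. Compound 3 `COc1ccc2c(c1C(=O)OCOC(=O)OC(C)C)OB(O)[C@@H](Sc1nncs1)C2` differs from compound 2 by isopropoxy in place of tert-butyl on a carbonyl carbon. For the measured compounds named here, the only measured step at this carbonyl carbon is a number 48 percentage points higher from compound 1 to compound 2 (beyond the scatter), with tert-butyl in place of methyl. Going by the values given here, it shows that a change at this place can move the number well past the scatter, but no measured compound carries isopropoxy. A moderate fall in this assay is expected, estimated as a number 20 percentage points lower from compound 2 to compound 3 (beyond the scatter). For compound 3 the expected value is 80%, with an estimated range of 55% to 100%.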

Compound 3, oral bioavailability: 94%
Compound 3: the middle estimate sits 14 percentage points below what was measured, within the range that was stated.
By their numbers in this assay, from the lowest: compound 1; then compounds 3 and 2 (each within the scatter of the next).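

In this assay the swap to isopropoxy on this carbonyl carbon reads as a number 6 percentage points lower from compound 2 to compound 3 (within the scatter) and so does not separate isopropoxy from tert-butyl. The other step reads as a number 42 percentage points higher from compound 1 to compound 3 (beyond the scatter) and shows that the high numbers at this place are not confined to tert-butyl, with methyl in compound 1 standing apart from both groups. Nothing at hand accounts for these readings.

Still open, from the compounds shown here alone, is how an amine or a longer chain such as n-hexyloxy on this carbonyl carbon would read.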